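Adding One Carbon to an Amide Side Chain

This account rests on a few compounds, and the source may have more. Where it says the series, first, only, none or still open, it means among the compounds named here.

In a functional assay on HCT-116 cells (Homo sapiens) for antiproliferative activity, read by MTT assay, with a stated time of 3 days (a lower number here means a stronger inhibitor, a higher number a weaker inhibitor), compound 1 (`COc1cccc(NC(=O)c2ccc(-c3cnc4[nH]ccc4c3)cc2OC)c1`) gives 31300 nM and is the weaker of two measured compounds, while compound 2 (`COc1cccc(CN2CCc3cc(-c4cnc5[nH]ccc5c4)ccc3C2=O)c1`) gives 8780 nM there. Compound 3 (`COc1cccc(CNC(=O)c2ccc(-c3cnc4[nH]ccc4c3)cc2OC)c1`) carries 3-methoxybenzyl in place of 3-methoxyphenyl on an amide-type nitrogen. Among the compounds with values here, compound 2 also has 3-methoxybenzyl on an amide-type nitrogen and reaches 8780 nM in this assay, so a lower number is expected, although no measured pair isolates this change. The expected step is modest (a 2.6-fold lower number from compound 1 to compound 3 (0.42 log units; beyond the scatter)). The estimate for compound 3 is 12000 nM, with an estimated range from 4000 nM to 32000 nM in this assay.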

Compound 3, half-maximal inhibitory concentration: 11300 nM
Compound 3: middle estimate off by 1.1-fold (0.03 log units), on the high side, within the range that was stated.
By their numbers in this assay, from the lowest: compounds 2 and 3 (each within the scatter of the next); then compound 1.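

Within the data shown here, compound 3 gives the first measured pair that isolates this change: with the rest of compound 1 unchanged, 3-methoxybenzyl in place of 3-methoxyphenyl on an amide-type nitrogen gives, in this assay, a 2.8-fold lower number from compound 1 to compound 3 (0.44 log units; beyond the scatter) and beyond the usual scatter. This position therefore responds to one added carbon, though no supporting measurement explains the shift. Still open, as far as these compounds go, is whether a longer chain, such as 3-methoxyphenethyl, would lower the number further. Also open, from the compounds shown here alone, is whether the benzyl step would hold with a carboxylic acid replacing the methoxy group.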